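A few compounds are considered here, and "the series" means these few. Any claim that something is new, unique, unknown or untested is made for them only; others in the source may bear on it.

Three compounds have been measured in a functional assay on HepG2 cells (Homo sapiens) for antiproliferative activity, read by MTT assay, with a stated time of 48 h; on this read-out higher numbers stand for weaker inhibition and lower numbers for stronger inhibition:

Compound 1 `Cc1cccc(NC(=O)Nc2cccc(CNc3nccnc3Cl)c2)c1` gives 11200 nM.
Compound 2 `O=C(Nc1ccc(C(F)(F)F)cc1)Nc1cccc(CNc2nccnc2Cl)c1` gives 5050 nM.
Compound 3 `O=C(Nc1cccc(CNc2nccnc2Cl)c1)Nc1cccc(C(F)(F)F)c1` gives 6210 nM.

Compound 1 holds the highest of these three numbers. The single-change step from it is a 1.8-fold lower number from compound 1 to compound 3 (0.26 log units; within the scatter), so the two cannot be ordered, and that change is trifluoromethyl in place of methyl on an aromatic carbon. Within the data shown here, compound 2 sits further off, beyond the scatter, but no single-change step links it to compound 1, so only the two values can be set side by side.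

Compound 4 `O=C(Nc1cccc(CNc2nccnc2Cl)c1)NC1CCCCC1` has not yet been measured. Its change from compound 1 is cyclohexyl in place of 3-methylphenyl on an amide-type nitrogen. Among the measured compounds shown here, no measured step speaks to this: the one step available, a 1.8-fold lower number from compound 1 to compound 3 (0.26 log units; within the scatter), swaps one group on an aromatic carbon for another and stays within the scatter, whereas here the whole 3-methylphenyl gives way to cyclohexyl. Without a comparable precedent, the direction cannot be read from the data, and the expectation is a step not clearly beyond the scatter, with a wide range. Compound 4 is therefore expected at 12000 nM, within a range of 4000 nM to 40000 nM. The expected step is a 1.1-fold higher number from compound 1 to compound 4 (0.03 log units; within the scatter).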

Compound 4, half-maximal inhibitory concentration: > 40000 nM
Compound 4: a limit, no number; the forecaster's own chance of this, stated with the estimate: 8%; at least 3.3-fold (0.52 log units) between middle value and limit.
By their numbers in this assay, from the lowest: compounds 2, 3 and 1 (each within the scatter of the next, the first and the last beyond it). At a limit, above all of these: compound 4.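

The earlier step swapped only a small group on the aromatic ring and stayed within the scatter, whereas replacing the whole 3-methylphenyl on this amide-type nitrogen in this assay gives an at least 3.5-fold higher number from compound 1 to compound 4 (0.55 log units; beyond the scatter), the only single-change step shown that goes beyond the scatter. Both groups are six-membered rings of carbon with no hydrogen-bond donors or acceptors, so such a ring alone does not preserve the read-out here; compounds 1, 2 and 3, which all have an aromatic ring at this place, give measured numbers. Compound 4 carries a limit, not a number: the limit of > 40000 nM in this assay, at which 1 of the 4 values shown sits.

This single change cannot separate the role of the aromatic ring from that of its methyl. As far as these compounds go, a plain phenyl, a benzyl or a cyclopentyl on this nitrogen remains open, as does the true value of compound 4.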